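From sec-butyl to benzyl on the aromatic oxygen

A few compounds are considered here, and "the series" means these few. Any claim that something is new, unique, unknown or untested is made for them only; others in the source may bear on it.

Of the compounds shown here, three sharing one core have been measured in a functional assay on the whole organism (strain Sprague-Dawley) for inhibition, with Rattus norvegicus as the target, with a stated time of 10 min; a lower number here means that less compound is needed, a higher number that more compound is needed for the effect. Compound 1 `CCOC(=O)c1cnc(-c2ccccc2O)[nH]c1=O` gives 5 mg/kg. Compound 2 `CCOC(=O)c1cnc(-c2ccccc2OC)[nH]c1=O` gives 10 mg/kg. Compound 3 `CCOC(=O)c1cnc(-c2ccccc2OC(C)CC)[nH]c1=O` gives 0.5 mg/kg, the lowest number of the three, and its gaps to both others lie beyond the scatter.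

The next compound, compound 4 `CCOC(=O)c1cnc(-c2ccccc2OCc2ccccc2)[nH]c1=O`, has benzyl in place of sec-butyl on an oxygen on an aromatic ring. All three measured steps bear on this change, since each falls at that same oxygen. Methyl in place of hydrogen gave a 2.0-fold higher number from compound 1 to compound 2 (0.30 log units; within the scatter). Sec-butyl in place of hydrogen gave a 10-fold lower number from compound 1 to compound 3 (1.00 log units; beyond the scatter), a modest step. Sec-butyl in place of methyl gave a 20-fold lower number from compound 2 to compound 3 (1.30 log units; beyond the scatter), a large one. Of the groups measured, only sec-butyl moved the number beyond the scatter. Among the compounds with values here, no measured compound carries a ring at this oxygen, so the benzyl step cannot be read directly from these data. A small step towards a higher number is therefore expected in this assay, with much of the lead of compound 3 retained. The estimated change is a 3.0-fold higher number from compound 3 to compound 4 (0.48 log units; beyond the scatter). For compound 4 the expected value is 1.5 mg/kg, within an estimated range from 0.4 mg/kg to 6 mg/kg.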

Compound 4, dose for 50% inhibition: > 5 mg/kg
Compound 4: no number, only a limit; the forecaster's own chance of this, stated with the estimate: 3%; at least 3.3-fold (0.52 log units) between middle value and limit.
By their numbers in this assay, from the lowest: compound 3; then compounds 1 and 2 (each within the scatter of the next).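

In this assay compound 4 gives > 5 mg/kg, which is a limit and not a number: the limit of > 5 mg/kg in this assay, at which 1 of the 4 values shown sits.

Benzyl in place of sec-butyl at this oxygen gives an at least 10-fold higher number from compound 3 to compound 4 (1.00 log units; beyond the scatter), so the low number of compound 3 does not carry over to a group with more heavy atoms and a six-membered aromatic ring. The earlier compounds shown here showed a lower number only on going to sec-butyl, and compound 4 now shows that this gain belongs to that group and not to any larger carbon group on the oxygen. Benzyl in place of hydrogen at this oxygen gives a number no lower from compound 1 to compound 4 (the limit leaves the size open). On these data alone, the step from compound 2 to compound 4 cannot be read, so how far benzyl stands from hydrogen and where it stands relative to methyl remain unknown.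

The compounds shown leave open whether the loss follows the aromatic ring of benzyl or simply the absence of the sec-butyl chain. A cyclohexylmethyl group or a longer chain such as n-pentyl on this oxygen would be needed to tell these two readings apart, and how either would behave is not known from these data.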